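Butyl to tert-butyl on the amide nitrogen

The compounds below may be only part of what the source reports. "The series", "measured", "known", "first", "only" and "open" are said of these compounds alone.

In a functional assay on A549 cells (Homo sapiens) for inhibition, read by sulforhodamine B assay, with a stated time of 72 h (on this read-out higher numbers stand for weaker inhibition and lower numbers for stronger inhibition), compound 1 (`Nc1sc(-c2ccc(Cl)cc2)c(-c2ccc(Cl)cc2)c1C(=O)N1CCOCC1`) gives 1870 nM and compound 2 (`CCCCNC(=O)c1c(N)sc(-c2ccc(Cl)cc2)c1-c1ccc(Cl)cc1`) gives 8170 nM as the higher of the two numbers, so compound 2 is the weaker inhibitor of the pair. Compound 3 (`CC(C)(C)NC(=O)c1c(N)sc(-c2ccc(Cl)cc2)c1-c1ccc(Cl)cc1`) has not yet been measured. It differs from compound 2 by one change (tert-butyl in place of butyl on an amide-type nitrogen) with tert-butyl in place of butyl on an amide-type nitrogen, the same atoms joined differently.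

Within the data shown here, the only measured step at this amide is a 4.4-fold higher number from compound 1 to compound 2 (0.64 log units; beyond the scatter) with butylamino in place of morpholin-4-yl on a carbonyl carbon. That step is modest and replaces the whole group on the carbonyl carbon, so it gives little guide to a change within the butyl group. Among the measured compounds shown here, no measured pair isolates such a change. No step beyond the scatter is therefore expected in this assay and neither direction is favoured. The estimated step is a 1.2-fold lower number from compound 2 to compound 3 (0.07 log units; within the scatter) and remains within the scatter. For compound 3 the estimated value is 7000 nM (expected range 2800 nM to 16000 nM).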

Compound 3, half-maximal inhibitory concentration: 8850 nM
Compound 3: middle estimate off by 1.3-fold (0.10 log units), on the low side; the measured number falls inside the stated range.
By their numbers in this assay, from the lowest: compound 1; then compounds 2 and 3 (each within the scatter of the next).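

In this assay, among these compounds, joining the same four carbons as tert-butyl rather than butyl on the amide-type nitrogen gives a 1.1-fold higher number from compound 2 to compound 3 (0.03 log units; within the scatter) and so puts the two compounds within the scatter of each other, which is the first reading of a change inside this group. Replacing morpholin-4-yl with (tert-butyl)amino on the carbonyl carbon gives a 4.7-fold higher number from compound 1 to compound 3 (0.68 log units; beyond the scatter) and replacing it with butylamino gives a 4.4-fold higher number from compound 1 to compound 2 (0.64 log units; beyond the scatter) in the same series, so both chain forms stand beyond the scatter from compound 1, and the gap seen with butylamino is not confined to that one chain. Nothing measured on these groups accompanies the cell numbers, so the result stands without an explanation.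

As far as these compounds go, what remains open is whether the gap to compound 1 belongs to the morpholin-4-yl ring as a whole, to its ring oxygen or to the amide hydrogen present in compound 2 and compound 3. Piperidin-1-yl on the carbonyl carbon would bear on the ring oxygen, while methyl or a hydroxyethyl chain on the amide-type nitrogen would show whether this position stays as flat beyond four-carbon groups.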